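A few compounds are considered here, and "the series" means these few. Any claim that something is new, unique, unknown or untested is made for them only; others in the source may bear on it.

Compound 1 `CC(=O)OC[C@H]1O[C@H](OC[C@H](Cn2cc(-c3ccc(-c4noc(NC5CCCCC5)n4)cc3)nn2)OC(C)=O)C=C[C@@H]1OC(C)=O` gives 79.8 ug/mL in an ADME assay on HepG2 cells (Homo sapiens) for cytotoxicity, read by MTT assay, with a stated time of 48 h; a higher number here means that more compound is tolerated, a lower number that less compound is tolerated. Compound 2 `CC(=O)OC[C@H]1O[C@H](OC[C@@H](Cn2cc(CN(c3nc(-c4ccccc4)no3)C3CCCCC3)nn2)OC(C)=O)C=C[C@@H]1OC(C)=O` gives 19.9 ug/mL. Compound 3 `C#CCN(c1nc(-c2ccc(C)cc2)no1)C1CCCCC1` gives 91.9 ug/mL.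

Among the three measured compounds, compound 2 stands lowest in this assay, with compound 1 and compound 3 both giving numbers beyond the scatter above it. Compound 4 `CC(=O)OC[C@H]1O[C@H](OC[C@@H](Cn2cc(CN(c3nc(-c4cccc([N+](=O)[O-])c4)no3)C3CCCCC3)nn2)OC(C)=O)C=C[C@@H]1OC(C)=O` has not yet been measured. It differs from compound 2 by one change: nitro in place of hydrogen on an aromatic carbon. Within the data shown here, no measured pair carries the same change, so there is nothing to show how this assay responds to it. The step from compound 2 to compound 4 is expected to be small, with no clear direction beyond the scatter, a 1.3-fold higher number from compound 2 to compound 4 (0.10 log units; within the scatter). Compound 4 is therefore estimated at 25 ug/mL, within a range from 10 ug/mL to 60 ug/mL.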

Compound 4, half-maximal cytotoxic concentration: > 200 ug/mL
Compound 4 was reported as a limit (the forecaster's own chance of this, stated with the estimate: 10%); middle value at least 8.0-fold (0.90 log units) away from the limit.
By their numbers in this assay, from the lowest: compound 2; then compounds 1 and 3 (each within the scatter of the next). At a limit, above all of these: compound 4.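

In this assay, among these compounds, nitro in place of hydrogen on the phenyl ring, the first change at this position that can be read, brings an at least 10-fold higher number from compound 2 to compound 4 (1.00 log units; beyond the scatter), so the assay does respond to a change at this position. The value of compound 4, > 200 ug/mL, is a limit of the assay: the limit of > 200 ug/mL in this assay, at which 1 of the 4 values shown sits.

Whether this response belongs to nitro alone stays open, as no other group, such as an amine or a carboxylic acid, is shown at this place. Also open, on these data alone, is whether nitro elsewhere on the ring would give the same result.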